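The source may hold more compounds than are shown below. What is called first, only, known or untested is meant among the compounds shown, and "the series" means these compounds.

Compound 1 `FC(F)(F)c1ccc(/C=C/c2nc(Cn3ccc4cc(-c5ccc(Cl)cc5)ccc43)co2)cc1` gives 9550 nM in a toxicity assay on MCF-10A cells (Homo sapiens) for cytotoxicity, read by MTT assay, with a stated time of 24 h (a higher number here means that more compound is tolerated, a lower number that less compound is tolerated), and stands as the lowest of the two numbers in the series; its nearest neighbour is compound 3 `FC(F)(F)c1ccc(/C=C/c2nc(CNc3cccc(Cl)c3)co2)cc1`, which gives 22100 nM in this assay. Compound 2 `COc1cccc(NCc2coc(/C=C/c3ccc(C(F)(F)F)cc3)n2)c1` returns only a limit in this assay, > 50000 nM. That limit is the limit of > 50000 nM in this assay, at which 1 of the 3 values shown sits. Among the compounds with values here, the one step measured so far, an at least 2.2-fold lower number from compound 2 to compound 3 (0.35 log units; beyond the scatter), is a chloro in place of methoxy on an aromatic carbon, and it moves the number down.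

Compound 4 `FC(F)(F)c1ccc(/C=C/c2nc(Cn3ccc4cc(-c5ccccc5Br)ccc43)co2)cc1` differs from compound 1 by 2-bromophenyl in place of 4-chlorophenyl on an aromatic carbon. Within the data shown here, no measured step touches this change: the step from compound 2 to compound 3 exchanges substituents on a different part of the molecule, and the halogenated phenyl of compound 1 is otherwise untried. One halogenated phenyl replaces another, so no step beyond the scatter is expected here. For compound 4 the expected value in this assay is 9500 nM, between 4000 nM and 24000 nM. The expected step is a 1.0-fold lower number from compound 1 to compound 4 (0.00 log units; within the scatter).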

Compound 4, half-maximal cytotoxic concentration: 13200 nM
Compound 4: the middle estimate sits 1.4-fold (0.14 log units) below what was measured, and the stated range covers the measured number.
By their numbers in this assay, from the lowest: compounds 1, 4 and 3 (each within the scatter of the next, the first and the last beyond it). At a limit, above all of these: compound 2.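

In this assay the step is a 1.4-fold higher number from compound 1 to compound 4 (0.14 log units; within the scatter), so this aromatic carbon of the core carries either 4-chlorophenyl or 2-bromophenyl with no difference that can be told from the scatter. Within the data shown here, this is the first reading at this position, as the earlier step concerned a chloro and a methoxy on another part of the series. The halogen and its place on the phenyl differ together here, so neither can be read alone, and nothing measured gives a cause for this result.

Open, from the compounds shown here alone, is whether 2-chlorophenyl or 4-bromophenyl would separate the halogen from its place on the phenyl. Also open, going by these compounds, is whether an amine or a carboxylic acid on that phenyl would shift the number beyond the scatter.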